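This account rests on a few compounds, and the source may have more. Where it says the series, first, only, none or still open, it means among the compounds named here.

In a physicochemical assay for solubility, measured as kinetic solubility, with a stated time of 1 h, at pH 7.4 (on this read-out higher numbers stand for higher solubility and lower numbers for lower solubility), compound 1 `CC(=O)NC1=NN(c2ccc(Cl)c(Cl)c2)CC1` gives 31000 nM and compound 2 `CC(=O)N[C@@H](C)C(=O)NC1=NN(c2ccc(Cl)c(Cl)c2)CC1` gives 58000 nM in the same test. That gap is no real difference, with a 1.9-fold higher number from compound 1 to compound 2 (0.27 log units; within the scatter) as the step. Compound 3 `O=C(NC1=NN(c2ccc(Cl)c(Cl)c2)CC1)c1cccnc1` gives 4000 nM and so lies clearly lower, with a 7.8-fold lower number from compound 1 to compound 3 (0.89 log units; beyond the scatter) and a 15-fold lower number from compound 2 to compound 3 (1.16 log units; beyond the scatter) as its steps. Compound 1 therefore stands level with compound 2 and well over compound 3. Compound 4 `CC(=O)NC1=NN(c2ccc(Cl)c(Cl)c2)C[C@H]1C` alters the core of compound 1 instead: methyl in place of hydrogen on a saturated ring carbon is the change. All measured steps swap the group on the carbonyl carbon, so none tests this ring carbon directly. A small downward shift, probably within the scatter, is expected, with a 1.4-fold lower number from compound 1 to compound 4 (0.15 log units; within the scatter) as the expected step. Compound 4 is estimated at 22000 nM within an expected range from 8000 nM to 50000 nM in this measurement.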

Compound 4, solubility: 36000 nM
Beside the measured number, compound 4's estimate is 1.6-fold (0.21 log units) below it, and the stated range covers the measured number.
By their numbers in this assay, from the lowest: compound 3; then compounds 1, 4 and 2 (each within the scatter of the next).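

Every earlier step swapped the group on the carbonyl carbon, whereas this one tests the ring itself: in this assay, methyl in place of hydrogen on a saturated ring carbon gives no real difference, with a 1.2-fold higher number from compound 1 to compound 4 (0.06 log units; within the scatter) as the step. On the core of compound 1, this ring carbon therefore carries one added methyl without a shift beyond the scatter. No measurement at hand explains this result. Going by these compounds, whether an ethyl group, a hydroxyl or an amine on the same ring carbon would also stay level with compound 1 remains open. So does whether the methyl would behave the same way in compound 3, which carries pyridin-3-yl on the carbonyl carbon.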